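This account rests on a few compounds, and the source may have more. Where it says the series, first, only, none or still open, it means among the compounds named here.

Measured so far in a toxicity assay on the whole organism with Rattus norvegicus as the target, at a dose of 200 mg/kg by the oral route; a lower number here means a weaker effect, a higher number a stronger effect of the compound at the dose given:

compound 1, `Brc1ccccc1OCC1=NCCO1`, gives 20%
compound 2, `Brc1ccc(OCC2=NCCO2)cc1`, gives 10%
compound 3, `Fc1ccc(OCC2=NCCO2)cc1`, gives 25%

Compound 1 gives neither the highest nor the lowest of these three numbers. Its gap to compound 3 and its gap to compound 2 both lie within the usual scatter of this kind of measurement, so the three compounds cannot be told apart with confidence on these numbers alone.

The step from compound 1 to compound 4, `Fc1ccccc1OCC1=NCCO1`, is a single exchange: fluoro in place of bromo on an aromatic carbon. Among the compounds with values here, one measured step bears directly on it. The same exchange has been made once before, though in a different place on the shared core: a number 15 percentage points higher from compound 2 to compound 3 (beyond the scatter). That step was modest but lay beyond the scatter, and it pointed upward. Carrying the same exchange over to compound 1 therefore gives reason to expect a rise of similar size, not a fall and not a flat result, while keeping in mind that a single earlier step is a thin basis.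

Compound 4 is thus expected to give about 35% in this assay, with a range from 20% to 50%. This estimate means a step of a number 15 percentage points higher from compound 1 to compound 4 (beyond the scatter), expected to mirror the earlier one.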

Compound 4, a percentage reported as activity, at one dose (the size of the read-out at that dose, not a potency): 15%
Beside the measured number, compound 4's estimate is 20 percentage points above it, and the stated range ends above it.
By their numbers in this assay, from the lowest: compounds 2, 4, 1 and 3 (each within the scatter of the next, the first and the last beyond it).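

Placed on an aromatic carbon ortho to a group of 7 heavy atoms, fluoro in place of bromo gives, in this assay, a number 5 percentage points lower from compound 1 to compound 4 (within the scatter), so at this position the exchange cannot be told apart from no change at all. Within the data shown here, the earlier compounds offered only one case of this exchange, and the second case shows that its outcome does not carry over unchanged from one place on the shared core to another: the same change on two cores in this assay, a number 15 percentage points higher (beyond the scatter) from compound 2 to compound 3 and a number 5 percentage points lower (within the scatter) from compound 1 to compound 4, 20 percentage points apart, beyond the scatter of two such steps With only two cases, this is a difference between two places and not a general rule about fluoro and bromo.

Only bromo and fluoro appear at this position among the compounds shown, so it remains open whether a quite different group there, such as an amine or a carboxylic acid, would move the number beyond the scatter. From the compounds shown here alone, it is also open whether a longer chain in place of the group of 7 heavy atoms would change what the exchange of bromo for fluoro does at this position.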